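Chain Length and Branching on a Hydroxyalkyl Side Chain

The compounds below may be only part of what the source reports. "The series", "measured", "known", "first", "only" and "open" are said of these compounds alone.

Measured compounds:
- compound 1, `COc1cc(Cc2nc3c(N)ncnc3n2CCO)cc(OC)c1OC`, 222000000 nM
- compound 2, `COc1cc(Cc2nc3c(N)ncnc3n2CCCCO)cc(OC)c1OC`, 76900000 nM
- compound 3, `COc1cc(Cc2nc3c(N)ncnc3n2CC(C)CO)cc(OC)c1OC`, 49100000 nM

Three compounds share one core and differ only in the hydroxyalkyl chain on the aromatic nitrogen. In a functional assay on MCF7 cells (Homo sapiens) for cytotoxicity (on this read-out higher numbers stand for an effect only at larger amounts of compound and lower numbers for an effect already at smaller amounts), compound 1 gives the highest of the three numbers, so it needs the largest amount for an effect. The step of a 2.9-fold lower number from compound 1 to compound 2 (0.46 log units; beyond the scatter) and the step of a 4.5-fold lower number from compound 1 to compound 3 (0.66 log units; beyond the scatter) both go beyond the scatter, each in the direction of an effect at smaller amounts. Between compound 2 and compound 3 the step of a 1.6-fold lower number from compound 2 to compound 3 (0.19 log units; within the scatter) stays within the scatter.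

Compound 4, `COc1cc(Cc2nc3c(N)ncnc3n2CC(C)CCCO)cc(OC)c1OC`, has not been measured. It differs from compound 1 by 4-hydroxy-1-methylbutyl in place of hydroxymethyl on a saturated chain carbon bound to an aromatic nitrogen. This change combines a longer chain, as in compound 2, with a methyl branch, as in compound 3. Both measured steps bearing on it lowered the number modestly, so a lower number is expected for compound 4 in this assay, by about a 6.3-fold lower number from compound 1 to compound 4 (0.80 log units; beyond the scatter). The estimate for compound 4 is 35000000 nM, with a range from 10000000 nM to 120000000 nM.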

Compound 4, half-maximal effective concentration: 8770000 nM
Compound 4: middle estimate off by 4.0-fold (0.60 log units), on the high side; measured number outside the range, below it.
By their numbers in this assay, from the lowest: compound 4; then compounds 3 and 2 (each within the scatter of the next); then compound 1.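

Combining the longer chain with the methyl branch in 4-hydroxy-1-methylbutyl gives the only large step so far in this assay, a 25-fold lower number from compound 1 to compound 4 (1.40 log units; beyond the scatter), and this chain also goes beyond each single change, with a 5.6-fold lower number from compound 3 to compound 4 (0.75 log units; beyond the scatter) and an 8.8-fold lower number from compound 2 to compound 4 (0.94 log units; beyond the scatter). Although compound 2 and compound 3 lie within the scatter of each other, the position therefore still allows a clear further drop in the number once both features are present. Extending the chain also has a similar size of effect with and without the methyl branch: the same change on two cores in this assay, a 2.9-fold lower number (0.46 log units; beyond the scatter) from compound 1 to compound 2 and a 5.6-fold lower number (0.75 log units; beyond the scatter) from compound 3 to compound 4, 1.9-fold (0.29 log units) apart, within the scatter of two such steps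

On these data alone, all four chains end in a hydroxy group, so it remains open whether an amine or a carboxylic acid at the chain end would serve as well. A longer chain would show whether the numbers keep falling beyond compound 4.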